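Acylhydrazone series: shared core, varied arylidene end

The source may hold more compounds than are shown below. What is called first, only, known or untested is meant among the compounds shown, and "the series" means these compounds.

Measured compounds:
compound 1 `O=C(N/N=C/c1cccc([N+](=O)[O-])c1)Nc1ccc(Oc2ccnc3[nH]ccc23)c(F)c1` — 3640 nM
compound 2 `COc1ccc(/C=N/NC(=O)Nc2ccc(Oc3ccnc4[nH]ccc34)c(F)c2)c(OC)c1OC` — 1450 nM
compound 3 `COc1ccc(/C=N/NC(=O)Nc2ccc(Oc3ccnc4[nH]ccc34)cc2)cc1` — 4300 nM

In a functional assay on A549 cells (Homo sapiens) for antiproliferative activity, read by MTT assay, with a stated time of 72 h (a higher number here means a weaker inhibitor, a lower number a stronger inhibitor), compound 1 gives 3640 nM, the second highest of the three numbers. Compound 3 sits nearest to it, within the scatter of repeated measurements, so no order between compound 1 and compound 3 can be read from these two values. Compound 2, with the lowest number, stands beyond the scatter from compound 1 and is the stronger inhibitor of that pair.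

The next compound, compound 4 `CN(C)CCn1cccc1/C=N/NC(=O)Nc1ccc(Oc2ccnc3[nH]ccc23)c(F)c1`, keeps the core of compound 1 and changes only the arylidene end: 1-(2-(dimethylamino)ethyl)-1H-pyrrol-2-yl in place of 3-nitrophenyl on a carbon with a double bond to nitrogen. Among the measured compounds shown here, no pair among the measured compounds isolates a change of this kind, so there is no measured step to lean on. The spread among compounds 1, 2 and 3 is modest, and the arylidene end has so far moved the number only within a narrow band. The step from compound 1 to compound 4 is therefore expected to be small, a 1.2-fold lower number from compound 1 to compound 4 (0.08 log units; within the scatter), with no direction beyond the scatter asserted. Compound 4 is estimated at 3000 nM, in the range 900 nM to 10000 nM.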

Compound 4, half-maximal inhibitory concentration: "not active" (no number reported)
For compound 4 the study gives words and no number; the estimate stays without a comparison.
By their numbers in this assay, from the lowest: compound 2; then compounds 1 and 3 (each within the scatter of the next).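

Among the compounds shown here, compound 4 is reported in words and without a number in this assay, so no step from compound 1 to compound 4 can be read. Nothing shown bears on this result. The compounds shown leave open how the 1-(2-(dimethylamino)ethyl)-1H-pyrrol-2-yl end compares with the 3-nitrophenyl end on the shared core.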